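Nitro in place of methyl on compound 2

The source may hold more compounds than are shown below. What is called first, only, known or untested is meant among the compounds shown, and "the series" means these compounds.

In a functional assay on RS4-11 cells (Homo sapiens) for inhibition, read by CCK-8 assay, with a stated time of 48 h, tested at 20 uM (on this read-out lower numbers stand for less inhibition of growth and higher numbers for more inhibition of growth at the one concentration tested), compound 1 (`N#C/C(=C\c1ccccc1OS(=O)(=O)c1ccc([N+](=O)[O-])cc1)C(=O)Nc1nnc(Cc2cccc3ccccc23)s1`) gives 58% and compound 2 (`Cc1ccc(Cc2nnc(NC(=O)/C(C#N)=C/c3ccccc3OS(=O)(=O)c3ccc(C)cc3)s2)cc1`) gives 66% within the scatter of compound 1. Compound 3 (`Cc1ccc(Cc2nnc(NC(=O)/C(C#N)=C/c3ccccc3OS(=O)(=O)c3ccc([N+](=O)[O-])cc3)s2)cc1`) has nitro in place of methyl on an aromatic carbon, turning (4-methylphenyl)sulfonyl into (4-nitrophenyl)sulfonyl. Within the data shown here, no step between measured compounds is available. Compound 1 also holds (4-nitrophenyl)sulfonyl but differs elsewhere. The change in this assay is expected to stay within the scatter, with no firm direction, because compound 1 gives 58% within the scatter of compound 2. The expected step (a number 4 percentage points lower from compound 2 to compound 3 (within the scatter)) is slight. Compound 3 is estimated at 62% with a range from 47% to 76% for this measurement.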

Compound 3, percent growth inhibition at one concentration: 64%
Compound 3: the middle estimate sits 2 percentage points below what was measured; measured number inside the range.
By their numbers in this assay, from the lowest: compounds 1, 3 and 2 (each within the scatter of the next).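

Turning (4-methylphenyl)sulfonyl into (4-nitrophenyl)sulfonyl in this assay gives a number 2 percentage points lower from compound 2 to compound 3 (within the scatter) and so shows no measurable effect of this change at this position. With (4-nitrophenyl)sulfonyl held constant, 4-methylphenyl in place of naphthalen-1-yl gives a number 6 percentage points higher from compound 1 to compound 3 (within the scatter) and so also stays inside the scatter. Nothing available bears on the cause of these results.

On these data alone, whether an amine or a carboxylic acid in place of that nitro would shift growth inhibition beyond the scatter remains open. So does whether these steps would hold at other concentrations.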